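The source may hold more compounds than are shown below. What is called first, only, known or untested is meant among the compounds shown, and "the series" means these compounds.

Working notes on the series. In a functional assay for inhibition of sodium/hydrogen exchanger (Oryctolagus cuniculus) (a higher number here means a weaker inhibitor, a lower number a stronger inhibitor), compound 1 `CCCCCc1cc(C)c(C(=O)N=C(N)N)cc1S(C)(=O)=O` gives 27 nM, compound 2 `CCSc1cc(C)c(C(=O)N=C(N)N)cc1S(C)(=O)=O` gives 5.9 nM, and compound 3 `Cc1cc(Sc2ccccc2)c(S(C)(=O)=O)cc1C(=O)N=C(N)N` gives 14 nM. Compound 3 holds the second highest number of the three; its distance to each neighbour is given by a 1.9-fold lower number from compound 1 to compound 3 (0.29 log units; within the scatter) and by a 2.4-fold higher number from compound 2 to compound 3 (0.38 log units; beyond the scatter). Compound 4 `Cc1cc(Nc2ccccc2)c(S(C)(=O)=O)cc1C(=O)N=C(N)N` differs from compound 3 by anilino in place of phenylsulfanyl on an aromatic carbon. Within the data shown here, no measured step exchanges a sulfur-linked group for a nitrogen-linked one on this aromatic carbon; the steps that alter this carbon, a 4.6-fold lower number from compound 1 to compound 2 (0.66 log units; beyond the scatter) and a 1.9-fold lower number from compound 1 to compound 3 (0.29 log units; within the scatter), were modest at most. A step within the scatter, in either direction, is therefore expected in this assay: no change at the digits printed from compound 3 to compound 4 (within the scatter). Compound 4 is estimated at 14 nM, between 5 nM and 40 nM.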

Compound 4, half-maximal inhibitory concentration: 21 nM
Compound 4: middle estimate off by 1.5-fold (0.18 log units), on the low side; the measured number falls inside the stated range.
By their numbers in this assay, from the lowest: compound 2; then compounds 3, 4 and 1 (each within the scatter of the next).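

Exchanging the sulfur link for a nitrogen link on this aromatic carbon, which adds a hydrogen-bond donor and keeps the phenyl ring, gives a step within the scatter (a 1.5-fold higher number from compound 3 to compound 4 (0.18 log units; within the scatter)). Anilino also stays within the scatter of pentyl (a 1.3-fold lower number from compound 1 to compound 4 (0.11 log units; within the scatter)) but lies apart from ethylsulfanyl (a 3.6-fold higher number from compound 2 to compound 4 (0.55 log units; beyond the scatter)), so compound 2 alone stands beyond the scatter of the other three in this assay. No measurement shown accounts for these steps.

Open, on these data alone, is whether phenoxy or benzyl at this carbon would stay level with compound 3 and compound 4. Also open, as far as these compounds go, is whether ethylamino would match the ethylsulfanyl of compound 2.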